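From Fluoro to Cyano: Compound 1 to Compound 4

A few compounds are considered here, and "the series" means these few. Any claim that something is new, unique, unknown or untested is made for them only; others in the source may bear on it.

Compound 1 `CC1CCN(c2c(S(=O)(=O)c3cccc(F)c3)cnc3ccc(F)cc23)CC1` was tested in an assay on isolated protein for displacement of a labelled ligand from metabotropic glutamate receptor 5 (Homo sapiens), with a stated time of 60 min, tested at 1 uM (a higher number here means more inhibition at the concentration tested (going by the name of the read-out), a lower number less inhibition), where compound 1 gives 76%. Among the three measured compounds it stands second highest: compound 3 `CC1CCN(c2c(S(=O)(=O)c3ccc(F)c(F)c3)cnc3cc(F)ccc23)CC1` gives 94%, and compound 2 `CC1CCN(c2c(S(=O)(=O)c3cccc(F)c3)cnc3ccc(Cl)cc23)CC1` gives 58%. Among the measured compounds shown here, the only measured single-point step, a number 18 percentage points lower from compound 1 to compound 2 (beyond the scatter), concerns a halogen on the shared core rather than the 3-fluorophenyl group, so it bears only loosely on the change considered here. Compound 4 `CC1CCN(c2c(S(=O)(=O)c3cccc(C#N)c3)cnc3ccc(F)cc23)CC1` differs from compound 1 by cyano in place of fluoro on an aromatic carbon, turning 3-fluorophenyl into 3-cyanophenyl. For the measured compounds named here, no measured step probes this group, so the expectation rests on compound 1 alone and allows a shift in either direction or none beyond the scatter. Compound 4 is expected to give 70%, with a range from 45% to 90%. This estimate means a number 6 percentage points lower from compound 1 to compound 4 (within the scatter).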

Compound 4, a percentage reported as inhibition, at one concentration (the size of the read-out at that concentration, not a potency): 93%
Estimate against measurement, compound 4: 23 percentage points below; the measured number lies above the stated range.
By their numbers in this assay, from the lowest: compound 2; then compound 1; then compounds 4 and 3 (each within the scatter of the next).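

In this assay, replacing 3-fluorophenyl with 3-cyanophenyl gives a number 17 percentage points higher from compound 1 to compound 4 (beyond the scatter) and so shows that the group on the sulfonyl can change the read-out. At this place on the ring, the two heavy atoms of cyano are accepted in place of the single fluorine, with no loss of inhibition. Nothing at hand explains the rise. As far as these compounds go, how an amine, a methoxy group or a carboxylic acid would fare at the same place remains open, as does whether the gain from cyano carries over to other halogen patterns on the shared core.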